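Adenine nucleoside hydrazones: biphenyl replacement for a fluorobenzyloxy group

This account rests on a few compounds, and the source may have more. Where it says the series, first, only, none or still open, it means among the compounds named here.

Measured compounds:
compound 1, `Nc1nc(N/N=C/c2ccc(OCc3ccc(F)cc3)cc2)nc2c1ncn2[C@@H]1O[C@H](CO)[C@@H](O)[C@H]1O`, 70 nM
compound 2, `CC(/C=N/Nc1nc(N)c2ncn([C@@H]3O[C@H](CO)[C@@H](O)[C@H]3O)c2n1)Cc1ccc(C(C)C)cc1`, 9500 nM
compound 3, `Nc1nc(N/N=C/c2ccc(-c3ccc(Br)cc3)o2)nc2c1ncn2[C@@H]1O[C@H](CO)[C@@H](O)[C@H]1O`, 4.5 nM

All three share the same nucleoside core carrying a hydrazone-linked aromatic arm, and all were run in an assay on CHO-K1 cells for displacement of a labelled ligand from adenosine receptor A1 (Homo sapiens), read by scintillation counting, with a stated time of 60 min; a higher number here means a weaker inhibitor, a lower number a stronger inhibitor. On the three numbers, compound 1 stands second highest. Compound 3 gives a lower number, and the gap between them lies beyond the scatter. Compound 2, whose arm is a branched alkyl chain rather than an aromatic ring directly on the hydrazone, gives a higher number than compound 1, again beyond the scatter. No pair among these three differs in only one place, so no single step can be read off directly.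

Compound 4, `Nc1nc(N/N=C/c2ccc(-c3ccccc3)cc2)nc2c1ncn2[C@@H]1O[C@H](CO)[C@@H](O)[C@H]1O`, is not yet measured. It differs from compound 1 as follows: phenyl in place of (4-fluorobenzyl)oxy on an aromatic carbon. The aromatic arm is thus shortened from a benzyloxy-linked ring to a directly attached ring, which brings it closer in shape to the two-ring arm of compound 3.

The step from compound 1 to compound 4 is expected to be modest, toward a lower number, at about a 1.8-fold lower number from compound 1 to compound 4 (0.24 log units; within the scatter). Compound 4 is estimated at 40 nM, with a range from 10 nM to 150 nM.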

Compound 4, inhibition constant: 7860 nM
Estimate against measurement, compound 4: 200-fold (2.29 log units) below; measured number above the stated range.
By their numbers in this assay, from the lowest: compound 3; then compound 1; then compounds 4 and 2 (each within the scatter of the next).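

In this assay, putting phenyl in place of (4-fluorobenzyl)oxy on this aromatic carbon, para to a large group, gives a 110-fold higher number from compound 1 to compound 4 (2.05 log units; beyond the scatter), so this position is highly sensitive to the identity of its substituent. Both groups carry one six-membered aromatic ring of carbon only, so the presence of such a ring at this position does not by itself hold the value of compound 1; the change also removes the oxygen, the fluorine and the carbon that separates the oxygen from the ring. No measurement shown here accounts for the size of this step.

Going by these compounds alone, the single step changes all of these features at once, so the share of each remains open: an unsubstituted benzyloxy group would isolate the fluorine, while a 2-phenylethyl chain would keep the spacing of the arm without the oxygen. Also open, as far as these compounds go, is how this position responds to other groups on the same carbon, such as a phenoxy group, a longer alkoxy chain or an amine-linked benzyl group, with the shared core and hydrazone unchanged.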